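Weak inhibitors at the edge of measurement

The source may report more compounds than this note shows. Statements on the series, on what has been measured and on what is new or still open speak of the compounds shown alone.

The compounds here share one core and differ in two places: the group on an aromatic carbon of that core and the group on the amide nitrogen. Compound 1 `Cc1noc(C)c1-c1nn(Cc2ccc(C(=O)NC3CC3)cc2)c(=O)c2ccccc12` sits at a limit of a functional assay on HepG2 cells (Homo sapiens) for antiproliferative activity, read by MTT assay, with a stated time of 72 h (a higher number here means a weaker inhibitor, a lower number a stronger inhibitor), giving > 100000 nM. Compound 2 `Cc1noc(C)c1-c1nn(Cc2ccc(C(=O)N3CCCCC3)cc2)c(=O)c2ccccc12` gives 97300 nM in this assay. Compound 3 `Cn1cc(-c2nn(Cc3ccc(C(=O)NC4CC4)cc3)c(=O)c3ccccc23)cn1` also reaches only a limit in this assay, > 100000 nM. So compound 3 stands where no number could be read, and the limit of > 100000 nM in this assay, at which 2 of the 3 values shown sit, shows that this is the usual outcome in this set.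

Compound 4 `Cn1cc(-c2nn(Cc3ccc(C(=O)NC4CCCC4)cc3)c(=O)c3ccccc23)cn1` differs from compound 3 by cyclopentyl in place of cyclopropyl on an amide-type nitrogen. The closest measured step changes the same amide group: an at least 1.0-fold lower number from compound 1 to compound 2 (0.01 log units; that floor lies within the scatter). The other step, a step that the two limits leave unreadable from compound 1 to compound 3, gives no readable size. Neither suggests that the amide substituent moves this assay beyond the scatter.

Compound 4 is therefore expected to stay at the same edge, an estimated 100000 nM (from 40000 nM to 300000 nM), which means an expected step of a number no higher from compound 3 to compound 4 (the limit leaves the size open).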

Compound 4, half-maximal inhibitory concentration: 84300 nM
Compound 4: the middle estimate sits 1.2-fold (0.07 log units) above what was measured; low and high end bracket the measured number.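

In this assay, cyclopentyl in place of cyclopropyl on the amide-type nitrogen gives an at least 1.1-fold lower number from compound 3 to compound 4 (0.07 log units; that floor lies within the scatter). The value for compound 3 is only a limit, > 100000 nM. For the compounds shown here, compound 4 therefore gives the only readable number here for a compound carrying 1-methyl-1H-pyrazol-4-yl, although the limit leaves the full size of this step open and the part that can be read does not go beyond the scatter.

As far as these compounds go, it remains open whether an amine, a carboxylic acid or a longer chain on the amide-type nitrogen would give a number clearly beyond the scatter from those seen so far. Limits also still mark much of this small set: the limit of > 100000 nM in this assay, at which 2 of the 4 values shown sit.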